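Swapping the Terminal Aryl Group of Compound 2

The source may report more compounds than this note shows. Statements on the series, on what has been measured and on what is new or still open speak of the compounds shown alone.

Measured so far in a functional assay on HCT-116 cells (Homo sapiens) for antiproliferative activity, read by MTT assay, with a stated time of 72 h; on this read-out lower numbers stand for stronger inhibition and higher numbers for weaker inhibition:
compound 1, `O=C(CCc1cccc2c1B(O)OC2)NCc1ccccc1`: > 100000 nM
compound 2, `O=C(CCc1cccc2c1B(O)OC2)Nc1cccc(-c2ccc(Cl)cc2)c1`: 380 nM

Compound 1 `O=C(CCc1cccc2c1B(O)OC2)NCc1ccccc1` returns only a limit in this assay, > 100000 nM, which is the limit of > 100000 nM in this assay, at which 1 of the 2 values shown sits. Among the measured compounds shown here, compound 2 `O=C(CCc1cccc2c1B(O)OC2)Nc1cccc(-c2ccc(Cl)cc2)c1` gives 380 nM in this assay; it is the only number among the two results, so compound 2 stands alone as the reference point. For the measured compounds named here, no pair of measured compounds differs in a single place, so no measured step guides the next change.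

Compound 3 `CC(=O)c1cccc(-c2cccc(NC(=O)CCc3cccc4c3B(O)OC4)c2)c1` has yet to be measured in this assay. It differs from compound 2 by 3-acetylphenyl in place of 4-chlorophenyl on an aromatic carbon. With nothing measured to calibrate such a swap, the step is expected to be modest, from compound 2 to compound 3 a 1.6-fold higher number from compound 2 to compound 3 (0.20 log units; within the scatter), in the direction of slightly weaker inhibition and perhaps not beyond the scatter. Compound 3 is therefore estimated to give about 600 nM in this assay, most likely between 150 nM and 3000 nM.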

Compound 3, half-maximal inhibitory concentration: 86 nM
Beside the measured number, compound 3's estimate is 7.0-fold (0.84 log units) above it; measured number below the stated range.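

In this assay, the terminal aryl group of compound 2 proves to be a place where a single change moves the read-out beyond the scatter: putting 3-acetylphenyl in place of 4-chlorophenyl gives a 4.4-fold lower number from compound 2 to compound 3 (0.65 log units; beyond the scatter). This aromatic carbon therefore accepts a group with 9 heavy atoms and 1 hydrogen-bond acceptor, against 7 heavy atoms and 0 hydrogen-bond acceptors in the group that leaves, and inhibition grows stronger rather than weaker. Nothing measured here accounts for the size or direction of this step.

The compounds shown leave open whether the gain belongs to the acetyl group itself or to the loss of the chlorine, as the two groups differ in both. Going by these compounds, it also remains open how an amine or a carboxylic acid in place of the acetyl group would read in this assay.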